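Nitro substitution on the benzothiazole of compound 3

The compounds below may be only part of what the source reports. "The series", "measured", "known", "first", "only" and "open" are said of these compounds alone.

Compound 3 `CCn1cc(-c2nc3ccccc3s2)c(=O)c2cc(F)c(N3CCN(C)CC3)cc21` gives 114000 nM in a functional assay on A2780 cells (Homo sapiens) for cytotoxicity, read by MTT assay, with a stated time of 48 h (on this read-out higher numbers stand for weaker inhibition and lower numbers for stronger inhibition), the highest of the three numbers in hand. Compound 1 `CCn1cc(-c2nc3ccccc3o2)c(=O)c2cc(F)c(N3CCN(C)CC3)cc21` gives 700 nM, and compound 2 `CCn1cc(-c2nc3ccccc3s2)c(=O)c2cc(F)c(N3CCNCC3)cc21` gives 11300 nM. The two measured steps both end at compound 3: a 160-fold higher number from compound 1 to compound 3 (2.21 log units; beyond the scatter), and a 10-fold higher number from compound 2 to compound 3 (1.00 log units; beyond the scatter).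

Compound 4 `CCn1cc(-c2nc3ccc([N+](=O)[O-])cc3s2)c(=O)c2cc(F)c(N3CCN(C)CC3)cc21` differs from compound 3 in one place: nitro in place of hydrogen on an aromatic carbon. The change sits on an aromatic carbon of the six-membered aromatic ring of carbon only, meta to a fused ring and para to a fused ring, a position not touched by any measured step. The step from compound 1 to compound 3 and the step from compound 2 to compound 3 alter the 1,3-benzothiazol-2-yl group itself or the amine nitrogen in a ring; neither tells how a nitro group on that ring shifts the read-out. Going by the values given here, with no bearing step, no change beyond the scatter is expected, and compound 4 is estimated at 110000 nM, within 30000 nM to 400000 nM, which amounts to an expected 1.0-fold lower number from compound 3 to compound 4 (0.02 log units; within the scatter).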

Compound 4, half-maximal inhibitory concentration: 4300 nM
Compound 4: the middle estimate sits 26-fold (1.41 log units) above what was measured, outside the stated range (below it).
By their numbers in this assay, from the lowest: compound 1; then compound 4; then compound 2; then compound 3.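

In this assay, nitro in place of hydrogen gives a 27-fold lower number from compound 3 to compound 4 (1.42 log units; beyond the scatter), so this carbon on the six-membered aromatic ring of carbon only is a place where substitution moves the read-out, and moves it towards stronger inhibition. The earlier steps shown here showed sensitivity only to exchange of the 1,3-benzothiazol-2-yl group and to methyl on the amine nitrogen in a ring; this step adds a third point of sensitivity on the shared core. Nothing in hand explains the size of this step.

On these data alone, whether the shift belongs to nitro itself or would also follow from an amine, a chlorine atom or a carboxylic acid on this carbon remains open. Also open, as far as these compounds go, is whether nitro has a similar effect on compound 2, which carries hydrogen on the ring amine nitrogen.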